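Notes on the nitrile-to-acid step from compound 1

The compounds below may be only part of what the source reports. "The series", "measured", "known", "first", "only" and "open" are said of these compounds alone.

Compound 1 `CCc1cc(C(C)=O)c(O)cc1OCCCCC#N` carries a terminal nitrile on the ether chain. In an assay on isolated protein for binding affinity to leukotriene B4 receptor 1 (Homo sapiens), tested at 1 uM (on this read-out higher numbers stand for more inhibition at the one concentration tested (going by the name of the read-out) and lower numbers for less inhibition), compound 1 gives 57%, the highest of the three numbers in hand. Compound 2 `CCCc1cc(C(C)=O)c(O)cc1OCCCCC#N` gives 37% in this assay, and compound 3 `CCCCc1cc(C(C)=O)c(O)cc1OCCCCC#N` gives 13%. Both measured moves away from compound 1 lower the read-out: a number 20 percentage points lower from compound 1 to compound 2 (beyond the scatter) and a number 44 percentage points lower from compound 1 to compound 3 (beyond the scatter); between the other two, a number 24 percentage points lower from compound 2 to compound 3 (beyond the scatter). All three steps concern the saturated chain on the ring and leave the ether chain untouched.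

Compound 4 `CCc1cc(C(C)=O)c(O)cc1OCCCC(C)(C)C(=O)O` keeps the core of compound 1 and alters only the end of the ether chain: 1-carboxy-1-methylethyl in place of cyanomethyl on a saturated chain carbon, three bonds along the chain from an oxygen on an aromatic ring. Within the data shown here, no measured step touches this position, so the steps above give no direct guide to the size or direction of this change; they show only that compound 1 is the best-placed starting point among the three. The expectation is therefore set from compound 1 alone and held with low confidence. For compound 4 the read-out in this assay is expected at 72%, within 40% to 95%. That expectation corresponds to an estimated a number 15 percentage points higher from compound 1 to compound 4 (beyond the scatter), a rise beyond the scatter.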

Compound 4, a percentage reported as inhibition, at one concentration (the size of the read-out at that concentration, not a potency): 43%
Beside the measured number, compound 4's estimate is 29 percentage points above it; the range from low to high includes it.
By their numbers in this assay, from the lowest: compound 3; then compounds 2 and 4 (each within the scatter of the next); then compound 1.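

In this assay, the end of the ether chain turns out to be a position that responds: 1-carboxy-1-methylethyl in place of cyanomethyl, on a saturated chain carbon, three bonds along the chain from an oxygen on an aromatic ring, gives a number 14 percentage points lower from compound 1 to compound 4 (beyond the scatter). Among these compounds, the earlier steps all concerned the saturated chain on the ring, so this is the first reading at the ether chain end, and it shows that exchanging the nitrile for this carboxylic acid group lowers the number without removing it, with compound 4 at 43% in this assay. No measurement at hand bears on what lies behind the fall.

The change replaces the nitrile and adds methyl branching in a single step, so the compounds shown do not separate the two, and an unbranched carboxylic acid, a primary amide or a tetrazole at the same chain end would be needed to do so. Also open, from the compounds shown here alone, is whether 1-carboxy-1-methylethyl behaves the same way with a propyl or butyl chain on the ring in place of ethyl, and how a shorter or longer ether chain would read.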